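A Methoxyphenyl Replaces Chlorophenyl Among Three Inactive Analogues

A few compounds are considered here, and "the series" means these few. Any claim that something is new, unique, unknown or untested is made for them only; others in the source may bear on it.

Three compounds share one core and differ only in the aryl group sitting on a nitrogen on an aromatic ring. Compound 1 `Cc1cnc(Nc2ccc(C(C)C)cc2)nc1Nc1nc2ccccc2s1` carries an isopropyl group on that aryl ring, compound 2 `Cc1cnc(Nc2ccc([N+](=O)[O-])cc2)nc1Nc1nc2ccccc2s1` a nitro group, and compound 3 `Cc1cnc(Nc2ccc(Cl)cc2)nc1Nc1nc2ccccc2s1` a chloro group. In a functional assay on PC-3 cells (Homo sapiens) for antiproliferative activity, read by MTT assay, with a stated time of 48 h (on this read-out lower numbers stand for stronger inhibition and higher numbers for weaker inhibition), compound 1 gives > 50000 nM, which is a limit of the assay and not a number. In this assay compound 2 gives > 50000 nM, again a limit. In this assay compound 3 gives > 50000 nM, also a limit. Because all three values sit at the same limit (the limit of > 50000 nM in this assay, at which 3 of the 3 values shown sit), the steps between them cannot be read: a step that the two limits leave unreadable from compound 1 to compound 2, a step that the two limits leave unreadable from compound 1 to compound 3 and a step that the two limits leave unreadable from compound 2 to compound 3. Compound 3 therefore stands at the limit, with no number to set it apart from the other two.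

Compound 4 `COc1cccc(Nc2ncc(C)c(Nc3nc4ccccc4s3)n2)c1` introduces the change (3-methoxyphenyl in place of 4-chlorophenyl on a nitrogen on an aromatic ring). Within the data shown here, none of the measured steps has a readable size, so none points in a direction for this change; the only guidance is that three different groups on the same ring all left the assay at its limit. For compound 4 the expected step is an at least 1.2-fold lower number from compound 3 to compound 4 (0.09 log units; that floor lies within the scatter). The estimate for compound 4 in this assay is 40000 nM, expected to fall between 8000 nM and 200000 nM, with a real chance that only a limit is reported once more.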

Compound 4, half-maximal inhibitory concentration: > 50000 nM
Compound 4 gave a limit, no number; the forecaster's own chance of this, stated with the estimate: 70%; middle value at least 1.2-fold (0.09 log units) from the limit.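

Among these compounds, no step to compound 4 can be read from compound 1, compound 2 or compound 3 in this assay, because all four compounds end at the same limit: the limit of > 50000 nM in this assay, at which 4 of the 4 values shown sit. The compounds shown leave open whether any group on that nitrogen would give a real number instead of a limit in this assay.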